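Isopropyl to ethyl on the aryl group of compound 3

A few compounds are considered here, and "the series" means these few. Any claim that something is new, unique, unknown or untested is made for them only; others in the source may bear on it.

Compound 3 `COc1ncc(C(F)(F)F)cc1CO[C@H]1[C@H](C(C)(C)C)[C@@H](C(=O)O)N(C(=O)[C@@H]2CCCCO2)[C@H]1c1ccccc1C(C)C` stands second of three in an assay on cells with Cystic fibrosis transmembrane conductance regulator variant F508del (Homo sapiens) as the target, read by voltage clamp, with a stated time of 24 h, in the presence of a further agent that is not named here (a lower number here means a smaller maximal response, a higher number a larger maximal response), where compound 3 gives 570%. Compound 1 `COc1ncc(C(F)(F)F)cc1CO[C@H]1[C@H](C(C)(C)C)[C@@H](C(=O)O)N(C(=O)C2CCCCC2)[C@H]1c1ccccc1` gives 650% and compound 2 `COc1ncc(C(C)(C)C)cc1CO[C@H]1[C@H](C(C)(C)C)[C@@H](C(=O)O)N(C(=O)C2CCCCC2)[C@H]1c1ccccc1` gives 455%. Within the data shown here, the only one-place step measured, a number 195 percentage points lower from compound 1 to compound 2 (beyond the scatter), concerns tert-butyl in place of trifluoromethyl on an aromatic carbon, a different site from the change at hand. Compound 4 `CCc1ccccc1[C@H]1[C@@H](OCc2cc(C(F)(F)F)cnc2OC)[C@H](C(C)(C)C)[C@@H](C(=O)O)N1C(=O)[C@@H]1CCCCO1` differs from compound 3 by hydrogen in place of methyl on a saturated chain carbon bound to an aromatic carbon and a saturated chain carbon. Among the measured compounds shown here, no measured step touches this site, so its weight in this assay is unknown; given the small size of the change, the expected step is one that stays within the usual scatter, a number 10 percentage points lower from compound 3 to compound 4 (within the scatter). Compound 4 is therefore estimated at 560%, with a range from 440% to 680%.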

Compound 4, largest response reached (Emax), in percent of the reference or control that the assay uses: 490%
The estimate for compound 4 lay 70 percentage points above the measured number; the measured number falls inside the stated range.
By their numbers in this assay, from the lowest: compound 2; then compound 4; then compound 3; then compound 1.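

In this assay, among these compounds, a number 80 percentage points lower from compound 3 to compound 4 (beyond the scatter) gives the first reading at this site: the aryl substituent is not a silent position, since isopropyl to ethyl, the loss of a single methyl, already moves the maximal response beyond the scatter. The data shown give no explanation for this step. From the compounds shown here alone, whether a methyl, a tert-butyl or a methoxy group in place of the ethyl would lower or raise the number remains open. So does whether the step holds when tert-butyl replaces trifluoromethyl on the aromatic carbon.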